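This account rests on a few compounds, and the source may have more. Where it says the series, first, only, none or still open, it means among the compounds named here.

Measured so far in an assay on membranes from lung (Cavia porcellus) for binding affinity to cysteinyl leukotriene receptor (Homo sapiens); a lower number here means a stronger inhibitor, a higher number a weaker inhibitor:
compound 1, `O=C(O)CCSC(SCCC(=O)O)c1ccccc1CCCCCCCCCCCC(F)(F)F`: 147 nM
compound 2, `O=C(O)CCSC(SCCC(=O)O)c1ccccc1CCCCCCCCC1CCCCC1`: 1960 nM
compound 3, `CCCCCCCCCCCOc1ccccc1C(SCCC(=O)O)SCCC(=O)O`: 287 nM

Compound 3 stands second highest of the three numbers in this assay. Its nearest neighbour is compound 1, and the gap between the two lies within the scatter, so no order between them is claimed. Compound 2 lies well beyond the scatter from compound 3, with a clearly higher number.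

Compound 4, `O=C(O)CCSC(SCCC(=O)O)c1ccccc1OCCCCCCCCCO`, has not yet been measured. It differs from compound 3 by hydroxy in place of ethyl on a saturated chain carbon, nine bonds along the chain from an oxygen on an aromatic ring.

Going by the values given here, only one measured step touches the far end of the chain on the shared core: a 13-fold higher number from compound 1 to compound 2 (1.12 log units; beyond the scatter). Among the compounds with values here, that step shows the terminus of the chain is not indifferent in this assay, and the one exchange recorded there raised the number strongly. The change to compound 4 is of a different kind, a shortened chain ending in a hydroxy group, so the size is uncertain, but a move toward a higher number is the expectation, given that compound 2 shows 1960 nM after a terminal exchange.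

Compound 4 is therefore expected at 1000 nM, in the range 300 nM to 4000 nM, an expected step of a 3.5-fold higher number from compound 3 to compound 4 (0.54 log units; beyond the scatter).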

Compound 4, inhibition constant: > 20000 nM
Compound 4 ended at the assay's limit; the forecaster's own chance of this, stated with the estimate: 5%; at least 20-fold (1.30 log units) between middle value and limit.
By their numbers in this assay, from the lowest: compounds 1 and 3 (each within the scatter of the next); then compound 2. At a limit, above all of these: compound 4.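

In this assay, hydroxy in place of ethyl on a saturated chain carbon, nine bonds along the chain from an oxygen on an aromatic ring, gives an at least 69-fold higher number from compound 3 to compound 4 (1.84 log units; beyond the scatter). The value of compound 4 is a limit of the assay and not a number: the limit of > 20000 nM in this assay, at which 1 of the 4 values shown sits. Before this, sensitivity at the chain end rested on a 13-fold higher number from compound 1 to compound 2 (1.12 log units; beyond the scatter) alone; the new step extends it to a chain joined through the ring oxygen, and shows that one exchange at the chain end can carry a compound to the limit.

Going by these compounds, the step removes ethyl and brings in hydroxy together, so the share of each stays open. A plain nonyl chain would address the loss of ethyl, while a methoxy group or an amine at the same chain end would test whether the result is specific to hydroxy.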